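The compounds below may be only part of what the source reports. "The series", "measured", "known", "first", "only" and "open" are said of these compounds alone.

Measured so far in a functional assay on the whole organism (strain albino) for inhibition, with Rattus norvegicus as the target, read by paw edema, with stated times of 30 min and 1 h, at a dose of 100 mg/kg by the oral route; on this read-out higher numbers stand for more inhibition at the one dose given (going by the name of the read-out) and lower numbers for less inhibition:
compound 1 `COc1ccc(C2CC(c3ccc(OC)c(OC)c3)=NN2)c(OC)c1` gives 38%
compound 2 `COc1ccc(C2CC(c3ccc(OC)c(OC)c3)=NN2C(=O)CBr)c(OC)c1` gives 53%
compound 3 `COc1ccc(C2=NN(C(=O)CO[N+](=O)[O-])C(c3ccco3)C2)cc1OC` gives 32%

Compound 3 stands lowest of the three numbers. The gap to compound 1 lies within the scatter, so the two cannot be ranked against each other; the gap to compound 2 lies beyond the scatter, with compound 2 the higher of the pair. Among the compounds with values here, the only single-point step measured in the set is a number 15 percentage points higher from compound 1 to compound 2 (beyond the scatter), which concerns the ring nitrogen and not either aryl group.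

Compound 4 `COc1ccc(C2CC(c3ccc(OC)c(OC)c3)=NN2C(=O)CO[N+](=O)[O-])c(OC)c1` differs from compound 3 by 2,4-dimethoxyphenyl in place of furan-2-yl on a saturated ring carbon. Within the data shown here, no measured pair in this set differs at that saturated ring carbon, so no step bears directly on the change. What the numbers do offer is that compound 4 carries the same two aryl groups as compound 2, together with an acyl group on the ring nitrogen, and compound 2 gives 53%; compound 3, the starting point, gives 32%. On that basis an upward step from compound 3, a number 13 percentage points higher from compound 3 to compound 4 (beyond the scatter), is expected, of a size comparable to the spread already seen. Compound 4 is estimated at 45%, with a range from 30% to 60%.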

Compound 4, a percentage reported as inhibition, in the whole organism at one dose (the size of the read-out at that dose, not a potency): 38%
Beside the measured number, compound 4's estimate is 7 percentage points above it; the measured number falls inside the stated range.
By their numbers in this assay, from the lowest: compounds 3, 1 and 4 (each within the scatter of the next); then compound 2.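

In this assay, within the data shown here, the first reading at the saturated ring carbon comes from 2,4-dimethoxyphenyl in place of furan-2-yl, which gives a number 6 percentage points higher from compound 3 to compound 4 (within the scatter) and so does not separate the two aryl groups while the ((nitrooxy)methyl)carbonyl group stays on the ring nitrogen. The acyl group now shows its own dependence on the chain end: nitrooxy in place of bromo gives a number 15 percentage points lower from compound 2 to compound 4 (beyond the scatter), and against the free ring nitrogen the nitrooxy compound shows no change at the digits printed from compound 1 to compound 4 (within the scatter), so the rise seen in a number 15 percentage points higher from compound 1 to compound 2 (beyond the scatter) belongs to the bromo compound and is not shared by the nitrooxy compound. No supporting measurement bears on the reason for either result.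

Among these compounds, whether furan-2-yl and 2,4-dimethoxyphenyl would also stay level with bromo on the chain remains open, since the one comparison at this ring carbon carries nitrooxy. Also open, on these data alone, is how an amine or a carboxylic acid on the saturated chain carbon bound to the carbonyl carbon would read in this assay, and whether a plain phenyl ring on the saturated ring carbon would fall with these aryl groups.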